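A few compounds are considered here, and "the series" means these few. Any claim that something is new, unique, unknown or untested is made for them only; others in the source may bear on it.

Working notes on the urea series. The three measured compounds share one core and differ only in the halogen on the fused ring of the indazole side. Compound 1 `O=C(Nc1ccc(-n2ncc3c(Cl)cccc32)cc1)Nc1ccc(Cl)c(C(F)(F)F)c1` gives 1300 nM in a functional assay on NCI-H460 cells (Homo sapiens) for cytotoxicity, read by MTT assay, with a stated time of 72 h; on this read-out lower numbers stand for stronger inhibition and higher numbers for weaker inhibition. Compound 2 `O=C(Nc1ccc(-n2ncc3c(Br)cccc32)cc1)Nc1ccc(Cl)c(C(F)(F)F)c1` gives 1300 nM in this assay, and the step of no change at the digits printed from compound 1 to compound 2 (within the scatter) shows no separation. Compound 3 `O=C(Nc1ccc(-n2ncc3c(F)cccc32)cc1)Nc1ccc(Cl)c(C(F)(F)F)c1` gives 3400 nM in this assay, which is the highest number of the three; the steps of a 2.6-fold higher number from compound 1 to compound 3 (0.42 log units; beyond the scatter) and a 2.6-fold higher number from compound 2 to compound 3 (0.42 log units; beyond the scatter) both lie beyond the scatter, so compound 3 is the weakest of the measured set.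

Compound 4 `O=C(Nc1ccc(-n2ncc3ccccc32)cc1)Nc1ccc(Cl)c(C(F)(F)F)c1` has not been measured. Its change from compound 3 is hydrogen in place of fluoro on an aromatic carbon, that is, 4-fluoro-1H-indazol-1-yl becomes 1H-indazol-1-yl. For the measured compounds named here, the measured steps show that going from bromo or chloro to fluoro raised the number modestly; removing the halogen altogether has no direct precedent here, but the direction of those steps points toward a further, modest rise or at most no change. The expected step is a 1.3-fold higher number from compound 3 to compound 4 (0.12 log units; within the scatter), with compound 4 estimated at 4500 nM in this assay, in the range 1800 nM to 11000 nM.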

Compound 4, half-maximal inhibitory concentration: 5500 nM
Compound 4: the middle estimate sits 1.2-fold (0.09 log units) below what was measured, and the stated range covers the measured number.
By their numbers in this assay, from the lowest: compounds 1 and 2 (each within the scatter of the next); then compounds 3 and 4 (each within the scatter of the next).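

With hydrogen on this aromatic carbon, the step of a 1.6-fold higher number from compound 3 to compound 4 (0.21 log units; within the scatter) in this assay does not separate the two, so fluoro and hydrogen cannot be told apart at this position. The halogen-free compound does give a baseline for the heavier halogens: the steps of a 4.2-fold higher number from compound 1 to compound 4 (0.63 log units; beyond the scatter) and a 4.2-fold higher number from compound 2 to compound 4 (0.63 log units; beyond the scatter) both lie beyond the scatter, which ties the lower numbers of the chloro and bromo compounds to the presence of those two halogens on this carbon rather than to the shared core. No measurement on hand accounts for this difference.

The compounds shown leave open how a methyl, a methoxy or an amine on this carbon would compare with chloro and bromo. Going by these compounds, whether iodo would continue to match those two also remains open.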